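The source may report more compounds than this note shows. Statements on the series, on what has been measured and on what is new or still open speak of the compounds shown alone.

Among the compounds with values here, compound 2 `COc1ccc(CS(=O)(=O)/C=C/c2ccc(F)cc2)cc1` gives 2000 nM in a functional assay on DLD-1 cells (Homo sapiens) for antiproliferative activity, read by trypan blue exclusion (a lower number here means a stronger inhibitor, a higher number a weaker inhibitor), and it is the only compound with an actual number in this assay. Compound 1 `COc1ccc(/C=C/S(=O)(=O)Cc2ccc(OC)cc2)cc1` reaches only the limit > 20000 nM in this assay. Within the data shown here, the single measured step, an at least 10-fold lower number from compound 1 to compound 2 (1.00 log units; beyond the scatter), swaps a methoxy for a fluoro and rests on that limit (the limit of > 20000 nM in this assay, at which 1 of the 2 values shown sits), so its true size stays open. Compound 3 `COc1ccc(CS(=O)(=O)/C=C/c2ccc(Cl)cc2)cc1` differs from compound 2 by chloro in place of fluoro on an aromatic carbon. Among the measured compounds shown here, no measured pair exchanges one halogen for another, so the step from compound 1 to compound 2 shows only that this position is felt and offers no direction for a chloro. A change no larger than the scatter, or a small one either way, is the most reasonable expectation in this assay. Compound 3 is expected to show a 1.3-fold lower number from compound 2 to compound 3 (0.12 log units; within the scatter). Compound 3 is therefore estimated at 1500 nM, with a range from 500 nM to 5000 nM.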

Compound 3, half-maximal inhibitory concentration: 3000 nM
Compound 3: middle estimate off by 2.0-fold (0.30 log units), on the low side; the measured number falls inside the stated range.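

In this assay the two halogens can now be compared directly, and a 1.5-fold higher number from compound 2 to compound 3 (0.18 log units; within the scatter) leaves them within the scatter of each other at this position, which the earlier step could not show. Chloro also stands apart from methoxy, with an at least 6.6-fold lower number from compound 1 to compound 3 (0.82 log units; beyond the scatter) as the step, so the difference first seen with fluoro is not confined to that one halogen. On these data alone, compound 1 stands at a limit, so the true size of this step stays open: the limit of > 20000 nM in this assay, at which 1 of the 3 values shown sits.

The compounds shown leave open whether an amine, a carboxylic acid or a nitrile at this position would stay close to the two halogens or move away from them. They also leave open what happens when the methoxy elsewhere in the shared core, carried by all three compounds, gives way to another group.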